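Growing a methyl into an isopropyl on compound 2

A few compounds are considered here, and "the series" means these few. Any claim that something is new, unique, unknown or untested is made for them only; others in the source may bear on it.

Compound 1 `Cc1ccc(CNc2nc(Nc3ccc(N4CCN(C)CC4)cn3)ncc2Cl)cc1` gives 18600 nM as its value
Compound 2 `Cc1ccc(Nc2nc(Nc3ccc(N4CCN(C)CC4)cn3)ncc2Cl)cc1` gives 4030 nM as its value
Compound 3 `CC(C)c1ccc(Nc2nc(Nc3ccc(N4CCN(C)CC4)cn3)ncc2Cl)cc1` is not yet measured

In a functional assay on MDA-MB-231 cells (Homo sapiens) for inhibition, read by CCK-8 assay, with a stated time of 48 h (a lower number here means a stronger inhibitor of growth, a higher number a weaker inhibitor of growth), compound 2 holds the lower of the two numbers. Compound 3 has isopropyl in place of methyl on an aromatic carbon. For the measured compounds named here, the only measured step (a 4.6-fold lower number from compound 1 to compound 2 (0.66 log units; beyond the scatter)) swapped 4-methylbenzyl for 4-methylphenyl, a different change, so it bears only loosely on this one and sets no firm size. A small expected step toward a lower number is therefore assumed, possibly none beyond the scatter (a 1.3-fold lower number from compound 2 to compound 3 (0.13 log units; within the scatter)). For compound 3 the estimated value is 3000 nM (expected range 1200 nM to 7500 nM).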

Compound 3, concentration for 50% growth inhibition: 7020 nM
Compound 3: the middle estimate sits 2.3-fold (0.37 log units) below what was measured; the measured number falls inside the stated range.
By their numbers in this assay, from the lowest: compounds 2 and 3 (each within the scatter of the next); then compound 1.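

In this assay the step, a 1.7-fold higher number from compound 2 to compound 3 (0.24 log units; within the scatter), leaves the two compounds indistinguishable, so this place, para to a large group, tolerates isopropyl as well as methyl. Even with the larger group, the 4-isopropylphenyl compound stays apart from the 4-methylbenzyl one, with a 2.6-fold lower number from compound 1 to compound 3 (0.42 log units; beyond the scatter) in this series. Nothing available explains these numbers. From the compounds shown here alone, whether an amine or a carboxylic acid at this place would shift the number stays open. So does whether a tert-butyl group or a longer chain would stay within the scatter of compound 2.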